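The source may hold more compounds than are shown below. What is called first, only, known or untested is meant among the compounds shown, and "the series" means these compounds.

Working notes on the series. The shared core of compound 1 `Nc1ncnn2c([C@@H]3O[C@H](CO)[C@@H](O)[C@H]3O)cc(-c3ccccc3)c12` carries a phenyl group; in a functional assay on HCT-116 cells (Homo sapiens) for antiproliferative activity, with a stated time of 72 h (a higher number here means a weaker inhibitor, a lower number a stronger inhibitor), compound 1 gives 82600 nM. Compound 2 `Nc1ncnn2c([C@@H]3O[C@H](CO)[C@@H](O)[C@H]3O)cc(-c3ccc(F)cc3)c12` carries 4-fluorophenyl instead and gives 42500 nM. Compound 3 `Nc1ncnn2c([C@@H]3O[C@H](CO)[C@@H](O)[C@H]3O)cc(-c3ccc(Cl)cc3)c12` carries 4-chlorophenyl and gives 59300 nM. All three numbers sit close together: a 1.9-fold lower number from compound 1 to compound 2 (0.29 log units; within the scatter), a 1.4-fold lower number from compound 1 to compound 3 (0.14 log units; within the scatter) and a 1.4-fold higher number from compound 2 to compound 3 (0.14 log units; within the scatter). Compound 3 thus stands second highest of the three, within the scatter of both neighbours.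

Compound 4 `Nc1ncnn2c([C@@H]3O[C@H](CO)[C@@H](O)[C@H]3O)cc(-c3ccsc3)c12` is the next step from compound 3: thiophen-3-yl in place of 4-chlorophenyl on an aromatic carbon. Within the data shown here, the steps that bear on it are those changing the group on the same aromatic carbon, a 1.4-fold lower number from compound 1 to compound 3 (0.14 log units; within the scatter) and a 1.4-fold higher number from compound 2 to compound 3 (0.14 log units; within the scatter), both within the scatter. On this evidence the swap of one aromatic ring for another at this position has so far produced no step beyond the scatter, so the step from compound 3 to compound 4 is expected to be small as well, estimated at a 1.0-fold higher number from compound 3 to compound 4 (0.01 log units; within the scatter). Compound 4 is therefore expected to give about 60000 nM in this assay, with a range from 20000 nM to 180000 nM.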

Compound 4, half-maximal inhibitory concentration: 45200 nM
Estimate against measurement, compound 4: 1.3-fold (0.12 log units) above; measured number inside the range.
By their numbers in this assay, from the lowest: compounds 2, 4, 3 and 1 (each within the scatter of the next).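

The change here is of the ring itself and not of a group on it: a five-membered aromatic ring with 1 hetero atom replaces a six-membered aromatic ring of carbon only, and in this assay all three resulting steps stay within the scatter (a 1.3-fold lower number from compound 3 to compound 4 (0.12 log units; within the scatter) and a 1.1-fold higher number from compound 2 to compound 4 (0.03 log units; within the scatter) and a 1.8-fold lower number from compound 1 to compound 4 (0.26 log units; within the scatter)). Across these four compounds, neither ring size nor a sulfur atom in the ring moves the number beyond the scatter at this position. No measured information bears on this result.

Going by these compounds, all four compounds carry an aromatic ring with no net charge here, so it stays open whether an amine, a carboxylic acid or a longer chain would give a step beyond the scatter. The shared core is also unchanged throughout, leaving the effect of changes there open.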